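A few compounds are considered here, and "the series" means these few. Any claim that something is new, unique, unknown or untested is made for them only; others in the source may bear on it.

Measured compounds:
Compound 1, `C=CCn1c2ccc([N+](=O)[O-])cc2c(=O)n1Cc1ccccc1`, gives 192000 nM in an ADME assay on L929 cells (Mus musculus) for cytotoxicity, read by resazurin assay, with a stated time of 48 h; on this read-out lower numbers stand for higher toxicity in this test and higher numbers for lower toxicity in this test.
Compound 2, `O=c1c2cc([N+](=O)[O-])ccc2n(CCO)n1Cc1ccccc1`, gives in this assay only the limit > 256000 nM.

For the measured compounds named here, compound 1 carries the only numerical value in this assay; the one further value shown is a limit. Going by the values given here, the single measured step is an at least 1.3-fold higher number from compound 1 to compound 2 (0.12 log units; that floor lies within the scatter), and its floor rests on (the limit of > 256000 nM in this assay, at which 1 of the 2 values shown sits). Compound 3, `CC(=O)n1c2ccc([N+](=O)[O-])cc2c(=O)n1Cc1ccccc1`, differs from compound 1 as follows: acetyl in place of allyl on an aromatic nitrogen. Among the compounds with values here, no measured step bears on an exchange on the aromatic nitrogen; the one measured step, an at least 1.3-fold higher number from compound 1 to compound 2 (0.12 log units; that floor lies within the scatter), concerns a saturated chain carbon and is itself small. Compound 3 is therefore expected to stay close to compound 1, with an expected step of a 1.0-fold higher number from compound 1 to compound 3 (0.02 log units; within the scatter) that need not exceed the scatter. The estimate for compound 3 in this assay is 200000 nM, ranging from 80000 nM to 450000 nM.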

Compound 3, concentration lethal to 50% of the cells: > 256000 nM
Compound 3 ended at the assay's limit; the forecaster's own chance of this, stated with the estimate: 35%; middle value at least 1.2-fold (0.10 log units) from the limit.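

Working notes on the aromatic nitrogen: the earlier step concerned a saturated chain carbon, whereas acetyl in place of allyl changes the group bound directly to this nitrogen, and in this assay it gives an at least 1.3-fold higher number from compound 1 to compound 3 (0.12 log units; that floor lies within the scatter). For compound 3 only a limit is available, > 256000 nM. The size of this step therefore stays unresolved, and the step between the 2-hydroxyethyl and acetyl groups cannot be read, because both compounds stop at the same limit: the limit of > 256000 nM in this assay, at which 2 of the 3 values shown sit.

From the compounds shown here alone, it remains open what an amine or a carboxylic acid at the end of a longer chain on this nitrogen would do to the number. Also open, going by these compounds, is how far the true numbers of compound 2 and compound 3 lie past the limit.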